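Compound 2 to compound 3: moving off the limit

The compounds below may be only part of what the source reports. "The series", "measured", "known", "first", "only" and "open" are said of these compounds alone.

In a functional assay on HCT-116 cells (Homo sapiens) (a higher number here means a weaker inhibitor, a lower number a stronger inhibitor), compound 1 `COc1cc(NC(C)CCCNC(=O)NCCCCCO)c2ncccc2c1` gives 29000 nM. Compound 2 `COc1cc(NC(C)CCCNC(=O)NC(CO)(CO)CO)c2ncccc2c1` gives > 100000 nM, which is a limit of the assay and not a number. Going by the values given here, the one measured step is an at least 3.4-fold higher number from compound 1 to compound 2 (0.53 log units; beyond the scatter), with 2-hydroxy-1,1-bis(hydroxymethyl)ethyl in place of 5-hydroxypentyl on an amide-type nitrogen. Going by these compounds, it lies beyond the scatter, and its full size is unknown.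

Compound 3 `COc1cc(NC(C)CCCNC(=O)N(CCO)CCO)c2ncccc2c1` differs from compound 2 by bis(2-hydroxyethyl)amino in place of (2-hydroxy-1,1-bis(hydroxymethyl)ethyl)amino on a carbonyl carbon. Here bis(2-hydroxyethyl)amino stands in place of (2-hydroxy-1,1-bis(hydroxymethyl)ethyl)amino on a carbonyl carbon. Among the compounds with values here, no measured step makes this exact change, so the evidence is indirect. The nearest number is that of compound 1 at 29000 nM.

The expected move is an at least 1.6-fold lower number from compound 2 to compound 3 (0.22 log units; that floor lies within the scatter), a small shift toward a lower number in this assay. For compound 3 the estimated value is 60000 nM, with an expected range of 25000 nM to 150000 nM.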

Compound 3, half-maximal inhibitory concentration: > 100000 nM
Compound 3: a limit, no number; the forecaster's own chance of this, stated with the estimate: 45%; middle value at least 1.6-fold (0.22 log units) away from the limit.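

In this assay compound 3 gives > 100000 nM, which is a limit of the assay and not a number. The replacement of 5-hydroxypentyl now has a second outcome at this position, a carbonyl carbon whose other neighbour is an amide-type nitrogen: an at least 3.4-fold higher number from compound 1 to compound 3 (0.53 log units; beyond the scatter), with bis(2-hydroxyethyl)amino entering in place of (5-hydroxypentyl)amino, so the loss seen with compound 2 is not confined to the 2-hydroxy-1,1-bis(hydroxymethyl)ethyl group. The step between compound 2 and compound 3 cannot be read because both sit at the same ceiling: the limit of > 100000 nM in this assay, at which 2 of the 3 values shown sit.

Going by these compounds, how far compound 2 and compound 3 lie past that limit remains unknown. Also open, on these data alone, is whether a longer chain such as 6-hydroxyhexyl, or a pentyl chain ending in an amine or a carboxylic acid, would improve on compound 1, at 29000 nM.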